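Swapping trifluoromethyl for fluoro on compound 2

The source may hold more compounds than are shown below. What is called first, only, known or untested is meant among the compounds shown, and "the series" means these compounds.

Compound 1 `COc1cnc(-c2ccccn2)nc1N(C)C1CCCC1` gives 180 nM
Compound 2 `COc1cnc(-c2ccccn2)nc1NCc1ccccc1C(F)(F)F` gives 230 nM
Compound 3 `COc1cnc(-c2ccccn2)nc1C1CCCC1` gives 1800 nM

In a functional assay on RAW264.7 cells (Mus musculus), with a stated time of 3 days (on this read-out higher numbers stand for weaker inhibition and lower numbers for stronger inhibition), compound 2 gives 230 nM and so sits within the usual scatter of compound 1, while compound 3 gives a clearly higher number (1800 nM) on the same read-out. Compound 4 `COc1cnc(-c2ccccn2)nc1NCc1ccccc1F` has fluoro in place of trifluoromethyl on an aromatic carbon and is otherwise the same as compound 2.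

Among the measured compounds shown here, the only measured step is a 10-fold higher number from compound 1 to compound 3 (1.00 log units; beyond the scatter) and it puts cyclopentyl in place of cyclopentyl(methyl)amino on an aromatic carbon. For the measured compounds named here, that is a different place from the trifluoromethyl group, so no measured step gives a direct size for this change. Compound 1 and compound 2 carry different amino groups, yet their values lie within the scatter of each other, and only compound 3, which has no amino group, stands apart. Because compound 4 keeps the amino link of compound 2 (230 nM), no step beyond the scatter is expected, and the data give no firm direction.

The estimated step is a 1.2-fold higher number from compound 2 to compound 4 (0.09 log units; within the scatter) and it remains a rough expectation. For compound 4 the expected value is 280 nM with an estimated range from 90 nM to 850 nM in repeat measurements.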

Compound 4, half-maximal inhibitory concentration: 130 nM
Compound 4: middle estimate off by 2.2-fold (0.33 log units), on the high side; the measured number falls inside the stated range.
By their numbers in this assay, from the lowest: compounds 4, 1 and 2 (each within the scatter of the next); then compound 3.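

In this assay the swap gives a 1.8-fold lower number from compound 2 to compound 4 (0.25 log units; within the scatter) and so stays within the usual scatter, which means that compound 2 and compound 4 cannot be told apart on this read-out. Among the compounds shown here, this is the first measured change on this aromatic carbon, ortho to a large group, and it shows that for this pair, going from the four heavy atoms of trifluoromethyl to the single heavy atom of fluoro leaves no difference that the assay can resolve. No measurement of any property of these two groups is available to explain this result.

The compounds shown leave open how a nitrile, a carboxylic acid or an amine would read on this same aromatic carbon, and whether a plain hydrogen there would read like fluoro and trifluoromethyl. They also leave open what a bulkier group such as tert-butyl would do in this place, so the two values here mark out no limit on what this carbon can carry.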